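Benzyl ether swap on a urea-linked benzimidazole pair

This account rests on a few compounds, and the source may have more. Where it says the series, first, only, none or still open, it means among the compounds named here.

Compound 1 `Cc1ccc(NC(=S)NC(=O)c2ccc(OCc3cccc(Cl)c3Cl)cc2)cc1-c1nc2ccccc2[nH]1`: > 100000 nM
Compound 2 `Cc1ccc(NC(=O)NC(=O)c2ccc(OCc3ccc(C(F)(F)F)cc3)cc2)cc1-c1nc2ccccc2[nH]1`: 16800 nM

Among the measured compounds shown here, in a functional assay on MNK45 cells (Homo sapiens) for inhibition, read by MTT assay, with a stated time of 48 h (on this read-out lower numbers stand for stronger inhibition and higher numbers for weaker inhibition), compound 2 gives 16800 nM, the only actual number among the values shown. Compound 1 in this assay returns > 100000 nM, which is a limit of the assay rather than a number, as recorded in the limit of > 100000 nM in this assay, at which 1 of the 2 values shown sits. For the measured compounds named here, compound 2 therefore stands alone as the single measured value, with nothing above or below it to rank against.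

Compound 3 `Cc1ccc(NC(=O)NC(=O)c2ccc(OCc3ccc(Cl)c(Cl)c3)cc2)cc1-c1nc2ccccc2[nH]1` has not yet been measured in this assay. It differs from compound 2 by 3,4-dichlorophenyl in place of 4-(trifluoromethyl)phenyl on a saturated chain carbon bound to an oxygen on an aromatic ring. Going by the values given here, no step between measured compounds covers this change, so there is no measured guide to its size; the expectation for this assay is a shift no larger than the scatter, in no preferred direction. On that basis compound 3 is expected to give 15000 nM, between 5000 nM and 50000 nM. That estimate means an expected step of a 1.1-fold lower number from compound 2 to compound 3 (0.05 log units; within the scatter).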

Compound 3, half-maximal inhibitory concentration: 5820 nM
The estimate for compound 3 lay 2.6-fold (0.41 log units) above the measured number; measured number inside the range.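

In this assay, the aryl group on the benzyl ether carries weight: 3,4-dichlorophenyl in place of 4-(trifluoromethyl)phenyl gives a 2.9-fold lower number from compound 2 to compound 3 (0.46 log units; beyond the scatter), a modest step. Among the compounds shown here, this is the first comparison here between two measured compounds that differ in one place, and it shows that the number moves with the group on a saturated chain carbon bound to an oxygen on an aromatic ring. Nothing shown accounts for the size or direction of this step.

On these data alone, it remains open whether either chlorine alone would give the same number, and how an amine or a carboxylic acid in place of the 3,4-dichlorophenyl would read. For the compounds shown here, compound 1 gives > 100000 nM, a limit of the assay, and it differs from compound 3 in more than one place, so no step to it can be read.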